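Swapping the N-aryl group on compound 3's triazinedione

A few compounds are considered here, and "the series" means these few. Any claim that something is new, unique, unknown or untested is made for them only; others in the source may bear on it.

Measured so far:
- compound 1 `COc1ccc(Nc2cc(Nc3ccc(Oc4ccncc4-c4cccnc4)c(F)c3)ncn2)cc1`: 2140 nM
- compound 2 `Fc1cc(Nc2cc(Nc3cccc(Cl)c3)ncn2)ccc1Oc1ccncc1-c1cccnc1`: 180 nM
- compound 3 `Cn1c(=O)c(C(=O)Nc2ccc(Oc3ccncc3-c3cccnc3)c(F)c2)nn(-c2ccccc2F)c1=O`: 610 nM

In a functional assay on A549 cells (Homo sapiens) for cytotoxicity, read by MTT assay, with a stated time of 72 h (a lower number here means a stronger inhibitor, a higher number a weaker inhibitor), compound 3 gives 610 nM, the second highest of the three numbers; compound 2 gives 180 nM and compound 1 gives 2140 nM. Compound 4 `Cn1c(=O)c(C(=O)Nc2ccc(Oc3ccncc3-c3cccnc3)c(F)c2)nn(-c2ccc(F)c(Cl)c2)c1=O` differs from compound 3 by 3-chloro-4-fluorophenyl in place of 2-fluorophenyl on an aromatic nitrogen. Within the data shown here, the only measured step, a 12-fold lower number from compound 1 to compound 2 (1.08 log units; beyond the scatter), also adds a chlorine to an aryl group, but on a different core and at a different attachment, so it bears on the present change only loosely. A smaller gain is therefore expected, a 1.9-fold lower number from compound 3 to compound 4 (0.28 log units; within the scatter). Compound 4 is estimated at 320 nM, between 110 nM and 950 nM.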

Compound 4, half-maximal inhibitory concentration: 12500 nM
The estimate for compound 4 lay 39-fold (1.59 log units) below the measured number, outside the stated range (above it).
By their numbers in this assay, from the lowest: compound 2; then compound 3; then compound 1; then compound 4.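

In this assay, the change at this aromatic nitrogen gives a 20-fold higher number from compound 3 to compound 4 (1.31 log units; beyond the scatter), so the core of compound 3 is highly sensitive to which aryl group sits there. A chlorine-bearing aryl group does not behave the same way everywhere: the earlier step, a 12-fold lower number from compound 1 to compound 2 (1.08 log units; beyond the scatter), went in the opposite direction, on a different core and at a different attachment. Nothing available here explains the loss.

The two aryl groups differ in both their halogens and where those halogens sit, so the contribution of each remains unclear. From the compounds shown here alone, how a plain phenyl or an ethyl group would behave on this nitrogen also remains open.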